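A few compounds are considered here, and "the series" means these few. Any claim that something is new, unique, unknown or untested is made for them only; others in the source may bear on it.

Working notes on the series. In a functional assay on A549 cells (Homo sapiens) for antiproliferative activity, read by MTT assay, with a stated time of 48 h (a higher number here means a weaker inhibitor, a lower number a stronger inhibitor), compound 3 `COc1cc(-c2nnc3c(OC4CCC4)cc(-c4ccc5c(ccn5C)c4)cn23)cc(OC)c1OC` gives 176 nM. This is level with compound 1 `COc1cc(-c2nnc3c(OC4CC4)cc(-c4ccc5[nH]ccc5c4)cn23)cc(OC)c1OC` at 198 nM and clearly lower than compound 2 `COc1cc(-c2nnc3c(OC4COC4)cc(-c4ccc5c(ccn5C)c4)cn23)cc(OC)c1OC` at 516 nM.

The next compound is compound 4 `COc1cc(-c2nnc3c(OC4CC4)cc(-c4ccc5c(ccn5C)c4)cn23)cc(OC)c1OC`, with cyclopropyl in place of cyclobutyl on an oxygen on an aromatic ring.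

Among the measured compounds shown here, no measured step makes this exact swap. The closest is a 2.9-fold lower number from compound 2 to compound 3 (0.47 log units; beyond the scatter), a modest change beyond the scatter, made at the same oxygen with cyclobutyl in place of oxetan-3-yl. That step replaced a different group, so it gives only a rough upper guide to size. Compound 1 also carries cyclopropyl on that oxygen and gives 198 nM, which supports a similar value for the new compound.

In this assay, no change beyond the scatter is therefore expected, and no direction is favoured. The estimated step is a 1.1-fold higher number from compound 3 to compound 4 (0.03 log units; within the scatter). Compound 4 is estimated at 190 nM, with an expected range of 95 nM to 380 nM.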

Compound 4, half-maximal inhibitory concentration: 168 nM
The estimate for compound 4 lay 1.1-fold (0.05 log units) above the measured number, and the stated range covers the measured number.
By their numbers in this assay, from the lowest: compounds 4, 3 and 1 (each within the scatter of the next); then compound 2.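

In this assay, cyclopropyl and cyclobutyl on this oxygen cannot be told apart (a 1.0-fold lower number from compound 3 to compound 4 (0.02 log units; within the scatter)), so removing one carbon from this carbon-only ring leaves the number within the scatter. The step from oxetan-3-yl to cyclopropyl (a 3.1-fold lower number from compound 2 to compound 4 (0.49 log units; beyond the scatter)) lies beyond the scatter, as does the earlier step to cyclobutyl (a 2.9-fold lower number from compound 2 to compound 3 (0.47 log units; beyond the scatter)), so with the N-methyl group held constant, both carbon-only rings separate from oxetan-3-yl. With cyclopropyl held constant, methyl in place of hydrogen on the aromatic nitrogen also shows no change beyond the scatter (a 1.2-fold lower number from compound 1 to compound 4 (0.07 log units; within the scatter)).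

No available data explain the separation of oxetan-3-yl from the two carbon-only rings. Going by these compounds, it also remains open whether a basic azetidin-3-yl amine or a longer n-butyl chain on this oxygen would stay level with compound 4.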